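The source may report more compounds than this note shows. Statements on the series, on what has been measured and on what is new or still open speak of the compounds shown alone.

Compound 1 `O=C(CCCCC#Cc1cccc(C(F)(F)F)c1)c1ncc(-c2ccccn2)o1` sets the reference point for this series. In an assay for inhibition of Fatty-acid amide hydrolase 1 (Rattus norvegicus) (on this read-out lower numbers stand for stronger inhibition and higher numbers for weaker inhibition), compound 1 gives 10 nM. Compound 2 `O=C(O)c1ccc(CCCCCCC(=O)c2ncc(-c3ccccn3)o2)cc1` carries a different group at the end of its chain. In this assay compound 2 reaches only a limit of the measurement, recorded as > 600 nM (the limit of > 600 nM in this assay, at which 1 of the 2 values shown sits), so its standing is known only as that limit and not as a number. Compound 3 `CSc1cccc(CCCCCCC(=O)c2ncc(-c3ccccn3)o2)c1` differs from compound 2 in one place: 3-(methylsulfanyl)phenyl in place of 4-carboxyphenyl on a saturated chain carbon, six bonds along the chain from a carbonyl carbon. Within the data shown here, no step between measured compounds connects these two structures, so the data give no direct measure of how large such a change is. The step from compound 2 to compound 3 is expected to be a substantial gain in inhibition, an at least 30-fold lower number from compound 2 to compound 3 (1.47 log units; beyond the scatter), beyond the usual scatter. For compound 3 in this assay an inhibition constant of 20 nM is estimated, with a range from 5 nM to 100 nM.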

Compound 3, inhibition constant: 4.2 nM
Estimate against measurement, compound 3: 4.8-fold (0.68 log units) above; measured number below the stated range.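

In this assay, among these compounds, 3-(methylsulfanyl)phenyl in place of 4-carboxyphenyl gives an at least 140-fold lower number from compound 2 to compound 3 (2.15 log units; beyond the scatter), the first measured step at this place on the chain. It shows that, with the rest of the structure unchanged, the group at the end of the chain can decide whether inhibition reaches the low nanomolar range or stays out of reach of a number. The size of the step is only a minimum, since compound 2 stands at a limit and not at a number: the limit of > 600 nM in this assay, at which 1 of the 3 values shown sits.

The exchange alters both the substituent and its ring position, so the pair does not separate the contribution of the carboxylic acid from that of the methylsulfanyl group. Going by these compounds, how an unsubstituted phenyl, a 3-carboxyphenyl or a 4-(methylsulfanyl)phenyl group would compare at this place remains open.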